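Moving the fluorine within the benzyl group of compound 2

The source may report more compounds than this note shows. Statements on the series, on what has been measured and on what is new or still open speak of the compounds shown alone.

Working notes on the series. In a functional assay on CCRF-CEM cells (Homo sapiens) for cytotoxicity, read by cell counting, with a stated time of 3 days (a higher number here means a weaker inhibitor, a lower number a stronger inhibitor), compound 1 `C=C(Br)C(=O)Nc1ccc(/C=C2\SC(=O)N(Cc3cccc(F)c3)C2=O)cc1` gives 3200 nM. In this assay compound 3 `Nc1ccc(/C=C2\SC(=O)N(Cc3cccc(F)c3)C2=O)cc1` gives 116000 nM, and compound 2 `Nc1cccc(/C=C2\SC(=O)N(Cc3cccc(F)c3)C2=O)c1` gives 250000 nM. Compound 2 therefore holds the highest number of the three measured compounds; its nearest neighbour is compound 3, a step beyond the scatter, and compound 1 lies far below it.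

The two measured steps are a 36-fold higher number from compound 1 to compound 3 (1.56 log units; beyond the scatter), which is large, and a 2.2-fold lower number from compound 2 to compound 3 (0.33 log units; beyond the scatter), which is modest. Both concern the aminophenyl side of the shared core. The step from compound 2 to compound 4 `Nc1cccc(/C=C2\SC(=O)N(Cc3ccc(F)cc3)C2=O)c1` is different: 4-fluorophenyl in place of 3-fluorophenyl on a saturated chain carbon bound to an amide-type nitrogen in a ring. Among the compounds with values here, no measured step touches the fluorophenyl group on the saturated chain carbon bound to the amide-type nitrogen in the ring, so nothing in the data speaks for or against a change at that position. The default expectation is therefore no step beyond the scatter in this assay, in either direction.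

For compound 4 the expected step is no change at the digits printed from compound 2 to compound 4 (within the scatter). In this assay compound 4 is estimated at 250000 nM, with a range from 100000 nM to 600000 nM.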

Compound 4, half-maximal inhibitory concentration: 87000 nM
Compound 4: the middle estimate sits 2.9-fold (0.46 log units) above what was measured, outside the stated range (below it).
By their numbers in this assay, from the lowest: compound 1; then compounds 4 and 3 (each within the scatter of the next); then compound 2.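

In this assay, the fluorophenyl position is not silent: with the 3-aminophenyl group held fixed, 4-fluorophenyl in place of 3-fluorophenyl gives a 2.9-fold lower number from compound 2 to compound 4 (0.46 log units; beyond the scatter), so a change in where the fluorine sits on this ring alone moves the number beyond the scatter. Within the data shown here, this is the first measured step on the saturated chain carbon bound to the amide-type nitrogen in the ring, and it is modest, like a 2.2-fold lower number from compound 2 to compound 3 (0.33 log units; beyond the scatter) on the aminophenyl side, whereas the only large step remains a 36-fold higher number from compound 1 to compound 3 (1.56 log units; beyond the scatter) on the nitrogen of the aromatic ring. Nothing among the data on hand accounts for the step at the fluorophenyl position, and its cause stays unassigned.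

Going by these compounds, it remains open whether the same fluorine change gives a step of similar size and direction on the 4-aminophenyl compound or on the compound carrying the (1-bromoethenyl)carbonyl group, since this single pair rests on the 3-aminophenyl group only. Also open, on these data alone, is how this position responds to a plain phenyl without fluorine, or to a chlorophenyl or methoxyphenyl group.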